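The source may report more compounds than this note shows. Statements on the series, on what has been measured and on what is new or still open speak of the compounds shown alone.

Measured compounds:
Compound 1 `CC(=O)c1ccc(NC(=O)Nc2ccc(F)c(C(F)(F)F)c2)cc1` gives 14 uL/min in an ADME assay on microsomes from liver (Mus musculus) for metabolic stability, using NADPH, with a stated time of 60 min; on this read-out lower numbers stand for slow clearance and higher numbers for fast clearance.
Compound 2 `N#Cc1ccc(NC(=O)Nc2ccnc(C(F)(F)F)c2)cc1` gives < 7 uL/min, which is a limit of this assay rather than a number.
Compound 3 `O=C(Nc1ccc(C(=O)O)cc1)Nc1ccc(F)c(C(F)(F)F)c1` gives < 7 uL/min, again a limit and not a number.

Compound 3 thus stands at the limit of < 7 uL/min in this assay, at which 2 of the 3 values shown sit. Compound 4 `N#Cc1ccc(NC(=O)Nc2ccc(F)c(C(F)(F)F)c2)cc1` differs from compound 3 by cyano in place of carboxy on an aromatic carbon. Within the data shown here, the only measured step, an at least 2.0-fold lower number from compound 1 to compound 3 (0.30 log units; that floor lies within the scatter), concerns hydroxy in place of methyl on a carbonyl carbon and does not bear directly on this swap. Compound 2, which also carries a cyano group, sits at the limit as well. No step beyond the scatter is therefore expected in this assay. Compound 4 is estimated at 7 uL/min, with a range from 4 uL/min to 14 uL/min. This estimate implies a step of a number no lower from compound 3 to compound 4 (the limit leaves the size open) that is expected to stay within the scatter.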

Compound 4, intrinsic clearance in a liver preparation (reported as CLH), per the amount of preparation that the assay uses: 12 uL/min
Beside the measured number, compound 4's estimate is 1.7-fold (0.23 log units) below it; the range from low to high includes it.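

Swapping carboxy for cyano on this aromatic carbon gives an at least 1.7-fold higher number from compound 3 to compound 4 (0.23 log units; that floor lies within the scatter). Swapping acetyl for cyano at the same place gives a 1.2-fold lower number from compound 1 to compound 4 (0.07 log units; within the scatter), so on this core this assay does not separate these two groups. The full size of the first step stays open, since compound 3 sits at a limit of the assay and not at a number: the limit of < 7 uL/min in this assay, at which 2 of the 4 values shown sit.

Still open, as far as these compounds go, is how an amine or a methoxy group on this carbon would read in this assay.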